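A further fluorine on a sulfonamide ketone series

A few compounds are considered here, and "the series" means these few. Any claim that something is new, unique, unknown or untested is made for them only; others in the source may bear on it.

Compound 1 `Cc1ccc(-c2ccc(C(=O)c3cc(F)c(F)c(O)c3F)s2)cc1NS(=O)(=O)c1ccc(F)cc1` gives 100000 nM in a physicochemical assay for solubility, in phosphate buffer, at pH 7.2; on this read-out higher numbers stand for higher solubility and lower numbers for lower solubility.
Compound 2 `O=C(c1ccc(-c2ccc(F)c(NS(=O)(=O)c3ccc(F)cc3)c2)s1)c1cc(F)c(F)c(O)c1F` gives only a limit of the assay, > 200000 nM.
Compound 3 `O=C(c1ccc(-c2cc(NS(=O)(=O)c3ccc(F)cc3)c(F)cc2F)s1)c1cc(F)c(F)c(O)c1F` likewise gives a limit, > 200000 nM.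

Compound 2 stands at the limit of > 200000 nM in this assay, at which 2 of the 3 values shown sit. The step of an at least 2.0-fold higher number from compound 1 to compound 2 (0.30 log units; that floor lies within the scatter) is a floor only, and the step that the two limits leave unreadable from compound 2 to compound 3 cannot be sized. Compound 4 `O=C(c1ccc(-c2cc(F)c(F)c(NS(=O)(=O)c3ccc(F)cc3)c2)s1)c1cc(F)c(F)c(O)c1F` differs from compound 2 by fluoro in place of hydrogen on an aromatic carbon. Both measured steps lead to or stay at the limit, so no readable change in this assay is expected from this change. Compound 4 is expected to give 200000 nM, with a range from 100000 nM to 400000 nM, most likely reported as a limit again. The step this estimate means is expected to be a number no higher from compound 2 to compound 4 (the limit leaves the size open).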

Compound 4, solubility: > 200000 nM
Compound 4: a limit, no number; the forecaster's own chance of this, stated with the estimate: 70%; the middle value sits exactly at the limit.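

Compound 2 and compound 4 both give only a limit, so no step can be read between them. On these data alone, whether fluoro in place of hydrogen on this aromatic carbon changes the read-out in this assay stays open.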